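Chloro to bromo on compound 3

This account rests on a few compounds, and the source may have more. Where it says the series, first, only, none or still open, it means among the compounds named here.

In a functional assay on A-431 cells (Homo sapiens) for inhibition, with a stated time of 72 h (a lower number here means a stronger inhibitor, a higher number a weaker inhibitor), compound 1 `Oc1c(CN2CCCC2)ccc2cccnc12` gives 16600 nM, compound 2 `CCN(CC)Cc1cc(Cl)c2cccnc2c1O` gives 9330 nM and compound 3 `Oc1c(CN2CCCC2)cc(Cl)c2cccnc12` gives 7410 nM. Compound 3 is clearly separated only from compound 1, since a 1.3-fold lower number from compound 2 to compound 3 (0.10 log units; within the scatter) stays within the scatter.

The open step leads to compound 4 `Oc1c(CN2CCCC2)cc(Br)c2cccnc12`, with bromo in place of chloro on an aromatic carbon para to a hydroxy group: bromo in place of chloro on an aromatic carbon. The (pyrrolidin-1-yl)methyl group stays as it is, so the amine swap above has little direct bearing. The closest evidence is the step that put chloro on that aromatic carbon, a 2.2-fold lower number from compound 1 to compound 3 (0.35 log units; beyond the scatter), and it is only modest. Among the measured compounds shown here, no bromo compound has been measured, and the data give no direction for a swap of one halogen for another. The expected move is a 1.1-fold lower number from compound 3 to compound 4 (0.02 log units; within the scatter), which means no change beyond the scatter is expected. For compound 4 the estimated value in this assay is 7000 nM, with an expected range of 3500 nM to 14000 nM.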

Compound 4, half-maximal inhibitory concentration: 4270 nM
The estimate for compound 4 lay 1.6-fold (0.21 log units) above the measured number; the range from low to high includes it.
By their numbers in this assay, from the lowest: compounds 4, 3, 2 and 1 (each within the scatter of the next, the first and the last beyond it).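

In this assay the swap on the aromatic carbon para to a hydroxy group gives a 1.7-fold lower number from compound 3 to compound 4 (0.24 log units; within the scatter) and so does not separate bromo from chloro at this position. Bromo in place of hydrogen on the same carbon gives a 3.9-fold lower number from compound 1 to compound 4 (0.59 log units; beyond the scatter) and stands clear of the scatter, so the modest gain over compound 1 is no longer seen with chloro alone. No measurement is available to explain either step.

As far as these compounds go, it remains open whether iodo would read like chloro and bromo on this carbon, and whether a nitrile or a methoxy group, neither of them a halogen, would keep the gain over compound 1. Also open, from the compounds shown here alone, is whether morpholin-4-yl in place of pyrrolidin-1-yl would change the number for compound 4.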